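Swapping Nitro for Cyclopropyl on the Acid-Bearing Ring

A few compounds are considered here, and "the series" means these few. Any claim that something is new, unique, unknown or untested is made for them only; others in the source may bear on it.

Measured so far:
compound 1, `OC[C@@H](O[C@H]1CCCN(Cc2nc3ccccc3[nH]2)[C@H]1c1ccccc1)c1cc(Cl)cc(Cl)c1`: 4700 nM
compound 2, `O=C(O)c1ccc(CN2CCC[C@H](O[C@H](CO)c3cc(Cl)cc(Cl)c3)[C@@H]2c2ccccc2)c([N+](=O)[O-])c1`: 520 nM

Both numbers come from an assay on isolated protein for activation of cGMP-dependent protein kinase 1 (Homo sapiens), read by ADP-Glo, with stated times of 30 min and 2 h, in the presence of a further agent that is not named here; on this read-out higher numbers stand for an effect only at larger amounts of compound and lower numbers for an effect already at smaller amounts. Going by the values given here, compound 2 gives the lower of the two, and the single measured step, a 9.0-fold lower number from compound 1 to compound 2 (0.96 log units; beyond the scatter), is the only comparison available. Compound 3, `O=C(O)c1ccc(CN2CCC[C@H](O[C@H](CO)c3cc(Cl)cc(Cl)c3)[C@@H]2c2ccccc2)c(C2CC2)c1`, differs from compound 2 by cyclopropyl in place of nitro on an aromatic carbon. Among the compounds with values here, no measured step touches a change of this kind, so nothing shows how large a step to expect in this assay or in which direction; a step within the scatter is the plain default. For compound 3 the estimate is 700 nM, within 200 nM to 3000 nM, meaning an expected step of a 1.3-fold higher number from compound 2 to compound 3 (0.13 log units; within the scatter).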

Compound 3, half-maximal effective concentration: 1800 nM
For compound 3 the middle estimate is 2.6-fold (0.41 log units) below the measured one, and the stated range covers the measured number.
By their numbers in this assay, from the lowest: compound 2; then compound 3; then compound 1.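

In this assay, this aromatic carbon is sensitive to which group it carries: cyclopropyl and nitro have the same count of heavy atoms, yet the exchange gives a 3.5-fold higher number from compound 2 to compound 3 (0.54 log units; beyond the scatter). Even with cyclopropyl, the ring bearing the carboxy group keeps an advantage over 1H-benzimidazol-2-yl, with a 2.6-fold lower number from compound 1 to compound 3 (0.42 log units; beyond the scatter). No supporting measurement is available to explain the size of either step. Going by these compounds, whether a nitrile, an amine or a methyl on the same aromatic carbon would come closer to compound 2 remains open, as does the contribution of the carboxy group itself.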